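The compounds below may be only part of what the source reports. "The series", "measured", "known", "first", "only" and "open" are said of these compounds alone.

Compound 1 `CCCCCCN1CCC(C(=O)Nc2cc(Cl)c(N)cc2OC)CC1`: in a functional assay on the whole organism for antagonist activity, with Mus musculus as the target (a higher number here means that more compound is needed for the effect, a lower number that less compound is needed), compound 1 gives > 10 mg/kg, a limit of the assay.
Compound 2 `COc1cc(N)c(Cl)cc1NC(=O)C1CCN(Cc2ccc(Cl)cc2)CC1`: in this assay compound 2 gives 1.2 mg/kg.

Compound 2 holds the only real number shown. The other value is a limit (the limit of > 10 mg/kg in this assay, at which 1 of the 2 values shown sits). Compound 3 `CCCN1CCC(C(=O)Nc2cc(Cl)c(N)cc2OC)CC1` differs from compound 2 by ethyl in place of 4-chlorophenyl on a saturated chain carbon bound to an amine nitrogen in a ring. For the measured compounds named here, the one measured step that bears on this, an at least 8.3-fold lower number from compound 1 to compound 2 (0.92 log units; beyond the scatter), ran the other way, from a plain chain to the 4-chlorophenyl, and was large. Reversing that direction, the expected step is a 10-fold higher number from compound 2 to compound 3 (1.00 log units; beyond the scatter), toward more compound needed, possibly reaching only a limit. Compound 3 is estimated at 12 mg/kg, between 3 mg/kg and 40 mg/kg.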

Compound 3, dose for half-maximal effect: > 10 mg/kg
Compound 3: only a limit was reported (the forecaster's own chance of this, stated with the estimate: 60%); the middle value does not contradict the limit.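

In this assay, the change from 4-chlorobenzyl to propyl gives an at least 8.3-fold higher number from compound 2 to compound 3 (0.92 log units; beyond the scatter). Compound 1 had shown this for one plain chain; with a shorter chain giving the same outcome, the advantage of compound 2 does not depend on a single chain length. The step between compound 1 and compound 3 cannot be read because both values are limits: the limit of > 10 mg/kg in this assay, at which 2 of the 3 values shown sit.

On these data alone, whether the benefit needs the ring or its chlorine remains open. An unsubstituted benzyl group or a cyclohexylmethyl group at this place would separate the two.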